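A few compounds are considered here, and "the series" means these few. Any claim that something is new, unique, unknown or untested is made for them only; others in the source may bear on it.

Among the measured compounds shown here, in a functional assay on MDA-MB-468 cells (Homo sapiens) for antiproliferative activity, read by MTT assay, with a stated time of 24 h (a higher number here means a weaker inhibitor, a lower number a stronger inhibitor), compound 2 `Cc1cccc(Nc2ncc(Br)c(Oc3cccc(F)c3)n2)c1` gives 29200 nM, the only true number among the values so far. Compound 1 `CNC(=O)c1ccccc1Oc1nc(Nc2ccccc2F)ncc1Br` gives > 50000 nM, which is a limit of the assay and not a number. Compound 3 `Cc1cccc(Nc2ncc(Br)c(Oc3cc(Cl)cc(Cl)c3)n2)c1` gives > 50000 nM, also a limit. Compound 4 `Cc1cccc(Nc2ncc(Br)c(Oc3cccc([N+](=O)[O-])c3)n2)c1` has nitro in place of fluoro on an aromatic carbon. For the measured compounds named here, one measured step bears on this change: an at least 1.7-fold higher number from compound 2 to compound 3 (0.23 log units; that floor lies within the scatter), with 3,5-dichlorophenyl in place of 3-fluorophenyl. Going by the values given here, with only that step as a guide, and with compound 2 at 29200 nM, no step beyond the scatter is expected in this assay. The estimate amounts to a 1.0-fold lower number from compound 2 to compound 4 (0.02 log units; within the scatter), an expected change within the scatter. For compound 4 the expected value is 28000 nM, with an estimated range of 11000 nM to 50000 nM.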

Compound 4, half-maximal inhibitory concentration: 36700 nM
For compound 4 the middle estimate is 1.3-fold (0.12 log units) below the measured one, and the stated range covers the measured number.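

In this assay, nitro in place of fluoro on an aromatic carbon gives a 1.3-fold higher number from compound 2 to compound 4 (0.10 log units; within the scatter). Unlike the earlier step, which rested on a limit, this one joins two true numbers. It shows that, in this pair, swapping one heavy atom for three, with two hydrogen-bond acceptors added, brings no step beyond the scatter. The compounds shown leave open what an amine, a carboxylic acid or a longer chain would do on this carbon. Room for reading further steps is also narrow: the limit of > 50000 nM in this assay, at which 2 of the 4 values shown sit.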